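The source may report more compounds than this note shows. Statements on the series, on what has been measured and on what is new or still open speak of the compounds shown alone.

In a functional assay on MCF7 cells (Homo sapiens) for antiproliferative activity, read by sulforhodamine B assay, with a stated time of 48 h (a higher number here means a weaker inhibitor, a lower number a stronger inhibitor), three compounds sharing one core have been measured. Compound 1 `CCCN1CCN(c2ccc(S(=O)(=O)Oc3ccccc3C)cc2)C1=O` reads > 100000 nM, a limit of the assay and not a number. Within the data shown here, compound 2 `CCCN1CCN(c2ccc(S(=O)(=O)Oc3ccccc3CC)cc2)C1=O` gives 2300 nM, and compound 3 `CCCN1CCN(c2ccc(S(=O)(=O)Oc3cccc(Cl)c3)cc2)C1=O` gives 380 nM, the lowest number so far. Compound 4 `CCCN1CCN(c2ccc(S(=O)(=O)Oc3ccc(Cl)cc3)cc2)C1=O` carries 4-chlorophenyl in place of 3-chlorophenyl on an oxygen. Among the measured compounds shown here, the steps that bear on this are a 6.1-fold lower number from compound 2 to compound 3 (0.78 log units; beyond the scatter), an at least 260-fold lower number from compound 1 to compound 3 (2.42 log units; beyond the scatter) and an at least 43-fold lower number from compound 1 to compound 2 (1.63 log units; beyond the scatter), all changes to the group on that oxygen, ranging from modest to large. None of them shows a move of the chlorine, so a modest rise in this assay is expected, given the low starting value of compound 3 at 380 nM. The estimated change is a 2.6-fold higher number from compound 3 to compound 4 (0.42 log units; beyond the scatter). Compound 4 is expected at about 1000 nM, within an estimated range of 200 nM to 6000 nM.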

Compound 4, half-maximal inhibitory concentration: 18000 nM
For compound 4 the middle estimate is 18-fold (1.26 log units) below the measured one; the whole stated range lies below it.
By their numbers in this assay, from the lowest: compound 3; then compound 2; then compound 4. At a limit, above all of these: compound 1.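

In this assay, moving the chlorine alone, with the atoms unchanged, gives a 47-fold higher number from compound 3 to compound 4 (1.68 log units; beyond the scatter), so the place of the chlorine on this ring weighs heavily on the oxygen bound to the sulfonyl sulfur. The 4-chlorophenyl group also reads worse than 2-ethylphenyl, with a 7.8-fold higher number from compound 2 to compound 4 (0.89 log units; beyond the scatter). The last step, an at least 5.5-fold lower number from compound 1 to compound 4 (0.74 log units; beyond the scatter), starts from a limit and not a number: the limit of > 100000 nM in this assay, at which 1 of the 4 values shown sits.

Still open, on these data alone, is how a bromine or a methoxy group in place of the chlorine would read in this assay.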